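The compounds below may be only part of what the source reports. "The series", "measured", "known", "first", "only" and "open" are said of these compounds alone.

Compound 1 `O=C1[C@@H](NS(=O)(=O)c2cc3ccnc(Cl)c3s2)CCN1CCNc1ccncc1` gives 23% in an assay on isolated protein for inhibition of coagulation factor X (Oryctolagus cuniculus), tested at 1 uM; on this read-out lower numbers stand for less inhibition and higher numbers for more inhibition at the one concentration tested (going by the name of the read-out). Compound 2 `O=C1[C@@H](NS(=O)(=O)c2cc3c(Cl)nccc3s2)CCN1Cc1cc2c[nH]ccc-2n1` gives 35%. Compound 3 `O=C1[C@@H](NS(=O)(=O)c2nc3cc(Cl)ccc3[nH]2)CCN1Cc1cc2c[nH]ccc-2n1` gives 31%.

On these three numbers compound 3 sits among the others: compound 2 lies a little higher and compound 1 a little lower, but both gaps are within the scatter, so the three cannot be told apart with confidence.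

Compound 4 `O=C1[C@@H](NS(=O)(=O)c2cc3ccnc(Cl)c3s2)CCN1Cc1cc2c[nH]ccc-2n1` differs from compound 3 in one place: a group of 10 heavy atoms (7 carbon, 1 nitrogen, 1 sulfur, 1 chlorine; one five-membered aromatic ring with 1 hetero atom, one six-membered aromatic ring with 1 hetero atom) in place of a group of 10 heavy atoms (7 carbon, 2 nitrogen, 1 chlorine; one five-membered aromatic ring with 2 hetero atoms, one six-membered aromatic ring of carbon only), on a sulfonyl sulfur. Going by the values given here, the only measured step that bears on this is the reverse exchange of the same two kinds of group, a number 4 percentage points lower from compound 2 to compound 3 (within the scatter), which stayed within the scatter. Compound 1 carries the same entering group on its sulfonyl sulfur, though its other end differs, and compound 1 gives 23%, also in the same region. The step expected here, a number 3 percentage points higher from compound 3 to compound 4 (within the scatter), is therefore none beyond the scatter. Compound 4 is estimated at 34%, with a range from 20% to 48%.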

Compound 4, a percentage reported as inhibition, at one concentration (the size of the read-out at that concentration, not a potency): 25%
The estimate for compound 4 lay 9 percentage points above the measured number; the range from low to high includes it.
By their numbers in this assay, from the lowest: compounds 1, 4, 3 and 2 (each within the scatter of the next, the first and the last beyond it).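

At the sulfonyl sulfur, replacing the 5-chloro-1H-benzimidazol-2-yl group gives a number 6 percentage points lower from compound 3 to compound 4 (within the scatter) in this assay, and exchanging one group for another with the same atom counts gives a number 10 percentage points lower from compound 2 to compound 4 (within the scatter), so neither exchange at this place produces a clear change. At the saturated chain carbon bound to an amide-type nitrogen in a ring, the other change gives a number 2 percentage points higher from compound 1 to compound 4 (within the scatter), which also leaves the read-out within the scatter. Nothing available explains these small steps.

Going by these compounds, it remains open whether a methoxy group in place of the chlorine, or a carboxylic acid on that saturated chain carbon, would give a step beyond the scatter. On these data alone, with a single tested concentration, it also remains open how these compounds compare in potency.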